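Methyl on the linking carbon of compound 2

A few compounds are considered here, and "the series" means these few. Any claim that something is new, unique, unknown or untested is made for them only; others in the source may bear on it.

Measured so far in a functional assay on HEK293 cells for agonist activity at Bile acid receptor (Homo sapiens); on this read-out lower numbers stand for an effect already at smaller amounts and higher numbers for an effect only at larger amounts of compound:
compound 1, `O=C(O)c1ccccc1OCc1ccc(OCc2c(-c3c(Cl)cccc3Cl)noc2C2CC2)nc1C(F)(F)F`: 1710 nM
compound 2, `O=C(O)c1cccc(OCc2ccc(OCc3c(-c4c(Cl)cccc4Cl)noc3C3CC3)nc2C(F)(F)F)c1`: 151 nM

Compound 2 holds the lower of the two numbers in this assay. Going by the values given here, the only measured step is an 11-fold lower number from compound 1 to compound 2 (1.05 log units; beyond the scatter); it concerns the carboxyphenyl and says nothing about the saturated carbon.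

Compound 3, `CC(Oc1cccc(C(=O)O)c1)c1ccc(OCc2c(-c3c(Cl)cccc3Cl)noc2C2CC2)nc1C(F)(F)F`, differs from compound 2 by methyl in place of hydrogen on a saturated chain carbon bound to an aromatic carbon and an oxygen on an aromatic ring. Among the compounds with values here, no measured step touches this carbon, so no direction can be read from the data. The expectation is therefore a step of about a 1.0-fold lower number from compound 2 to compound 3 (0.00 log units; within the scatter), not beyond the scatter. Compound 3 is estimated at 150 nM, with a range from 50 nM to 500 nM.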

Compound 3, half-maximal effective concentration: 107 nM
For compound 3 the middle estimate is 1.4-fold (0.15 log units) above the measured one, within the range that was stated.
By their numbers in this assay, from the lowest: compounds 3 and 2 (each within the scatter of the next); then compound 1.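

Methyl in place of hydrogen on this saturated chain carbon is accepted in this assay, with a 1.4-fold lower number from compound 2 to compound 3 (0.15 log units; within the scatter), so this carbon can carry a methyl without a shift beyond the scatter. The large separation from the 2-carboxyphenyl series also persists with 1-(3-carboxyphenoxy)ethyl in place of (2-carboxyphenoxy)methyl, with a 16-fold lower number from compound 1 to compound 3 (1.20 log units; beyond the scatter). No evidence bearing on this result is available.

Still open, on these data alone, is whether this carbon also accepts an ethyl, a hydroxyl or a second methyl, and whether any of these would move the number beyond the scatter.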